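Working notes: propyl to butyl on a shared core

The compounds below may be only part of what the source reports. "The series", "measured", "known", "first", "only" and "open" are said of these compounds alone.

Measured so far, all in a functional assay on Caco-2 cells (Homo sapiens), read by fluorescence, tested at 1 uM; on this read-out lower numbers stand for a stronger effect and higher numbers for a weaker effect at the one concentration tested:
compound 1 `CCCNC(=C\C(=O)/C=C/c1ccc(O)c(OC)c1)/C=C/c1ccc(O)c(OC)c1` gives 97%
compound 2 `COc1cc(/C=C/C(=O)CC(=O)/C=C/c2ccc(OC(C)=O)c(OC)c2)ccc1OC(C)=O` gives 93%
compound 3 `CCC(C)NC(=C\C(=O)/C=C/c1ccc(O)cc1)/C=C/c1ccc(O)cc1` gives 102%

Compound 1 stands second highest of the three numbers. Compound 2 is its nearest neighbour, a little lower, and compound 3 the furthest, a little higher; both gaps are within the usual scatter of this assay, so no order among the three compounds can be read from these numbers, and none of them can be called more or less active than another.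

Compound 4 `CCCCNC(=C\C(=O)/C=C/c1ccc(O)c(OC)c1)/C=C/c1ccc(O)c(OC)c1` is the next compound for this assay. It differs from compound 1 by methyl in place of hydrogen on a saturated chain carbon, three bonds along the chain from an amine nitrogen; read one bond further out, the change is propyl to butyl. Among the measured compounds shown here, no pair of measured compounds shares this kind of change, so nothing measured here gives a size for the step. The three measured compounds, which differ from one another in several places at once, still sit within the scatter of each other in this assay. On that basis the step from compound 1 to compound 4 is expected to be no change at the digits printed from compound 1 to compound 4 (within the scatter), no step beyond the scatter in either direction.

Compound 4 is therefore estimated at 97% in this assay, with a range from 85% to 108%.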

Compound 4, a percentage reported as activity, at one concentration (the size of the read-out at that concentration, not a potency): 91%
Estimate against measurement, compound 4: 6 percentage points above, and the stated range covers the measured number.
By their numbers in this assay, from the lowest: compounds 4, 2, 1 and 3 (each within the scatter of the next, the first and the last beyond it).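

The first measured size for this change at this position comes from the butyl analogue: in this assay, replacing hydrogen with methyl on a saturated chain carbon, three bonds along the chain from an amine nitrogen, gives a number 6 percentage points lower from compound 1 to compound 4 (within the scatter), so propyl to butyl on this shared core is a step that stays inside the noise of the read-out at the one concentration tested. The earlier compounds shown here differ from one another in several places at once and could offer only an indirect expectation, whereas this pair isolates a single change and shows that, for this one pair, adding the methyl leaves compound 1 and compound 4 without a readable order. Nothing available here bears on why the step has this size.

The compounds shown leave open whether a longer chain such as hexyl, a cyclohexyl group, or a carboxylic acid at the end of the chain would produce a step beyond the scatter on this core. They also leave open whether propyl to butyl would behave the same way on a core other than that of compound 1, since this change is seen in one pair only.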